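Compound 3 to compound 4: one group exchanged

The source may hold more compounds than are shown below. What is called first, only, known or untested is meant among the compounds shown, and "the series" means these compounds.

Measured in an ADME assay on Vero 76 cells (Chlorocebus sabaeus) for cytotoxicity, read by MTT assay, with a stated time of 96 h; on this read-out higher numbers stand for lower toxicity in this test and lower numbers for higher toxicity in this test:
Compound 1 `Cc1ccc(C2CC(c3ccccc3)=NN2c2ccc(S(N)(=O)=O)cc2)cc1`: 20000 nM
Compound 2 `NS(=O)(=O)c1ccc(N2N=C(c3ccccc3)CC2c2ccccc2Cl)cc1`: 26000 nM
Compound 3 `NS(=O)(=O)c1ccc(N2N=C(c3ccc(OCc4ccccc4)cc3)CC2c2ccccc2Cl)cc1`: 92000 nM

Compound 3 holds the highest number of the three at 92000 nM, and its distance from each of the other two lies beyond the usual scatter. Compound 4 `Cc1cccc(C2CC(c3ccc(OCc4ccccc4)cc3)=NN2c2ccc(S(N)(=O)=O)cc2)c1` has yet to be measured. It differs from compound 3 in one place, with 3-methylphenyl in place of 2-chlorophenyl on a saturated ring carbon.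

The closest evidence is an exchange on that same carbon, a 1.3-fold higher number from compound 1 to compound 2 (0.11 log units; within the scatter), which stayed within the scatter. Going by the values given here, there, 2-chlorophenyl entered in place of 4-methylphenyl, and the benzyloxy group was absent, so no measured pair tests such an exchange with benzyloxy present. The larger step, a 3.5-fold higher number from compound 2 to compound 3 (0.55 log units; beyond the scatter), came with benzyloxy in place of hydrogen on an aromatic carbon, and compound 4 keeps that benzyloxy group. No step beyond the scatter is therefore expected in this assay. The expected step is a 1.2-fold lower number from compound 3 to compound 4 (0.06 log units; within the scatter), with no firm direction. Compound 4 is estimated at 80000 nM, with an expected range of 40000 nM to 150000 nM.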

Compound 4, half-maximal cytotoxic concentration: 100000 nM
The estimate for compound 4 lay 1.3-fold (0.10 log units) below the measured number; measured number inside the range.
By their numbers in this assay, from the lowest: compounds 1 and 2 (each within the scatter of the next); then compounds 3 and 4 (each within the scatter of the next).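

In this assay, 3-methylphenyl in place of 2-chlorophenyl on a saturated ring carbon gives a 1.1-fold higher number from compound 3 to compound 4 (0.04 log units; within the scatter), so with the benzyloxy group present this exchange does not separate the two compounds. The earlier exchange on the same carbon, a 1.3-fold higher number from compound 1 to compound 2 (0.11 log units; within the scatter), also stayed within the scatter, but without benzyloxy; this position has now shown no step beyond the scatter in either setting, for the three aryl groups shown. The step that came with benzyloxy, a 3.5-fold higher number from compound 2 to compound 3 (0.55 log units; beyond the scatter), was seen with 2-chlorophenyl only, and compound 4 now shows that a benzyloxy compound carrying 3-methylphenyl stands within the scatter of compound 3.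

Nothing available here accounts for this flat response at the position. As far as these compounds go, it remains open whether a group of another kind on this carbon, such as a cyclohexyl ring or an aryl ring bearing an amine or a carboxylic acid, would move the number, and whether 3-methylphenyl would read the same without the benzyloxy group.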